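Methoxy to hydroxy on two cores in one series

The source may hold more compounds than are shown below. What is called first, only, known or untested is meant among the compounds shown, and "the series" means these compounds.

Compound 1 `COc1ccc(C2CC(c3cccc4ccccc34)=NN2C(C)=O)cc1OC` and compound 2 `COc1cc(C2CC(c3cccc4ccccc34)=NN2C(C)=O)ccc1O` share one core; compound 3 `COc1ccc(C2CC(c3ccc4ccccc4c3)=NN2CC=O)cc1OC` and the not yet measured compound 4 `COc1ccc(C2CC(c3ccc4ccccc4c3)=NN2CC=O)cc1O` share another. The difference between the two cores is not broken down here. In a functional assay on PC-3 cells (Homo sapiens) for cytotoxicity, read by sulforhodamine B assay, with a stated time of 48 h (on this read-out higher numbers stand for weaker inhibition and lower numbers for stronger inhibition), compound 1 gives 2010 nM, and compound 2 gives 2130 nM. Compound 3 gives 1980 nM in this assay. The three numbers sit close together, and no order among them is claimed.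

The change from compound 1 to compound 2 is hydrogen in place of methyl on an oxygen on an aromatic ring and it carried a 1.1-fold higher number from compound 1 to compound 2 (0.03 log units; within the scatter). The change from compound 3 to compound 4 is hydrogen in place of methyl on an oxygen on an aromatic ring. The two place descriptions read the same word for word, so this is the same change made on a second core; it occurs twice among the compounds shown, and only the first instance has a measurement.

The expectation for compound 4 rests on compound 3 with its value 1980 nM and on the earlier step of a 1.1-fold higher number from compound 1 to compound 2 (0.03 log units; within the scatter), which stayed within the scatter. In this assay the expected step is a 1.1-fold higher number from compound 3 to compound 4 (0.03 log units; within the scatter), beside the earlier one. Within the data shown here, only one prior instance of the change exists, so the range is kept wide. Compound 4 is accordingly estimated at 2100 nM, with a range from 1300 nM to 3400 nM.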

Compound 4, half-maximal inhibitory concentration: 2040 nM
Beside the measured number, compound 4's estimate is 1.0-fold (0.01 log units) above it, within the range that was stated.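

Methoxy to hydroxy on the core of compound 3 comes out in this assay as a 1.0-fold higher number from compound 3 to compound 4 (0.01 log units; within the scatter). Set beside the same change on the core of compound 1, the step carries over from one core to the other without a measurable difference: the same change on two cores in this assay, a 1.1-fold higher number (0.03 log units; within the scatter) from compound 1 to compound 2 and a 1.0-fold higher number (0.01 log units; within the scatter) from compound 3 to compound 4, 1.0-fold (0.01 log units) apart, within the scatter of two such steps

This shows only that, on these two cores and in this one assay, hydrogen in place of methyl on this oxygen leaves the number within the scatter; two instances make no rule for a further core, and as neither step lies beyond the scatter, the series offers no case of a sizeable effect of this change that could be tested for transfer.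

The compounds shown carry only methyl or hydrogen on this oxygen, so it remains open whether a longer chain such as ethyl or propyl, or a chain ending in an amine or a carboxylic acid, would leave the number equally unmoved. Going by these compounds, the two cores also differ in more than one place, so what each of those differences contributes on its own remains open as well.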